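The source may hold more compounds than are shown below. What is called first, only, known or untested is meant among the compounds shown, and "the series" means these compounds.

Compound 1 `COc1cc(C2=NN(C(C)=O)C(c3c(Cl)cccc3Cl)O2)cc(OC)c1OC` gives 5.1% in a functional assay on PC-3 cells (Homo sapiens) for antiproliferative activity, read by MTT assay, tested at 1 uM; a lower number here means a weaker effect, a higher number a stronger effect of the compound at the concentration tested.
Compound 2 `COc1cc(C2=NN(C(C)=O)C(c3cc(Cl)cc(Cl)c3)O2)cc(OC)c1OC` gives 52.7%.
Compound 3 `COc1ccc(C2OC(c3cc(OC)c(OC)c(OC)c3)=NN2C(C)=O)c(OC)c1` gives 69.5%.

Compound 3 stands highest of the three measured compounds in this assay; compound 2 is nearest, with a number 16.8 percentage points higher from compound 2 to compound 3 (beyond the scatter), and compound 1 is furthest, with a number 64.4 percentage points higher from compound 1 to compound 3 (beyond the scatter). Compound 4 `COc1ccc(OC)c(C2OC(c3cc(OC)c(OC)c(OC)c3)=NN2C(C)=O)c1` has not yet been measured. It differs from compound 3 by 2,5-dimethoxyphenyl in place of 2,4-dimethoxyphenyl on a saturated ring carbon. All three measured steps exchange the group on that same saturated ring carbon, and each lay beyond the scatter: a number 47.6 percentage points higher from compound 1 to compound 2 (beyond the scatter) and a number 16.8 percentage points higher from compound 2 to compound 3 (beyond the scatter) show that such an exchange can shift the read-out markedly. Going by the values given here, none of them, however, swaps one dimethoxyphenyl for another, so no measured step speaks directly to this change. A smaller step than those seen is therefore expected, leaning downward but possibly within the scatter. Compound 4 is expected to give 60%, with a range of 35% to 80%. This estimate means a step of a number 9.5 percentage points lower from compound 3 to compound 4 (within the scatter).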

Compound 4, a percentage reported as inhibition, at one concentration (the size of the read-out at that concentration, not a potency): 37.2%
Beside the measured number, compound 4's estimate is 22.8 percentage points above it; measured number inside the range.
By their numbers in this assay, from the lowest: compound 1; then compound 4; then compound 2; then compound 3.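

In this assay, exchanging 2,4-dimethoxyphenyl for 2,5-dimethoxyphenyl on the saturated ring carbon, with the same atoms joined differently, gives a number 32.3 percentage points lower from compound 3 to compound 4 (beyond the scatter), so the arrangement of the two methoxy groups alone can shift the read-out at this position. A dimethoxyphenyl group does not by itself surpass 3,5-dichlorophenyl here, as the 2,5-isomer shows a number 15.5 percentage points lower from compound 2 to compound 4 (beyond the scatter), though it still exceeds 2,6-dichlorophenyl, with a number 32.1 percentage points higher from compound 1 to compound 4 (beyond the scatter). Nothing available explains these differences. The compounds shown leave open how an aminophenyl or carboxyphenyl group on this carbon would read out, and whether a longer chain could replace the acetyl group.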